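Replacing the amide substituent in a pancreatic-cell series

The source may hold more compounds than are shown below. What is called first, only, known or untested is meant among the compounds shown, and "the series" means these compounds.

Compounds measured so far:
compound 1 `CCN(CC)S(=O)(=O)c1ccc(S(=O)(=O)N2CCC[C@@H](C(=O)N[C@H]3CC[C@H](OC)CC3)C2)cc1` — 2000 nM
compound 2 `CCN(CC)S(=O)(=O)c1ccc(S(=O)(=O)N2CCC[C@@H](C(=O)N[C@H]3CC[C@@H](OC)CC3)C2)cc1` — 2150 nM

In a functional assay on BXPC-3 cells (Homo sapiens) for inhibition, read by MTT assay, with a stated time of 7 days (a lower number here means a stronger inhibitor, a higher number a weaker inhibitor), compound 1 gives 2000 nM and compound 2 gives 2150 nM. For the measured compounds named here, the only measured step is a 1.1-fold higher number from compound 1 to compound 2 (0.03 log units; within the scatter), and it is a step of configuration alone, because of the fact that compounds 1 and 2 differ only in the configuration as drawn; the two numbers sit within the scatter of each other, so compound 2 is not distinguished from compound 1 on these data.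

Compound 3 `CCN(CC)S(=O)(=O)c1ccc(S(=O)(=O)N2CCC[C@@H](C(=O)N3CC[C@H](OC)C3)C2)cc1` is not yet measured. Its change from compound 2 is 3-methoxypyrrolidin-1-yl in place of (4-methoxycyclohexyl)amino on a carbonyl carbon: the ring that leaves carries the amide hydrogen, while the ring that enters is bonded to the carbonyl through its own nitrogen and carries no hydrogen-bond donor. Going by the values given here, no measured step touches this part of the molecule; the single step known concerns only stereochemistry and was within the scatter. The expectation therefore rests on compound 2 alone, and a step of modest size, estimated as a 1.4-fold higher number from compound 2 to compound 3 (0.14 log units; within the scatter), is expected. For compound 3 the estimate in this assay is 3000 nM, with a range from 1000 nM to 10000 nM.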

Compound 3, half-maximal inhibitory concentration: 6750 nM
Compound 3: middle estimate off by 2.3-fold (0.35 log units), on the low side; low and high end bracket the measured number.
By their numbers in this assay, from the lowest: compounds 1 and 2 (each within the scatter of the next); then compound 3.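

Changing the amide substituent moves the number in this assay in a way that changing configuration did not: 3-methoxypyrrolidin-1-yl in place of (4-methoxycyclohexyl)amino on a carbonyl carbon gives a 3.1-fold higher number from compound 2 to compound 3 (0.50 log units; beyond the scatter) and also a 3.4-fold higher number from compound 1 to compound 3 (0.53 log units; beyond the scatter), which makes compound 3 the weakest inhibitor of the three. Both steps beyond the scatter describe one replacement, reached from two starting points that the assay does not tell apart and that are related in a simple way: the fact that compounds 1 and 2 differ only in the configuration as drawn. This position therefore responds to a change of the substituent itself, although the step is modest and the replacement alters several things at once: the ring size, the hetero atom in the ring, and the loss of the amide hydrogen.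

Which of those changes accounts for the step remains open, and a 4-methoxypiperidin-1-yl group, with a six-membered ring bonded to the carbonyl through its own nitrogen, or a (3-methoxycyclopentyl)amino group, with a five-membered carbon ring that keeps the amide hydrogen, would help separate them. Also open, as far as these compounds go, is whether the opposite configuration of the 3-methoxypyrrolidin-1-yl stereocentre gives a different number from compound 3 .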